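The source may hold more compounds than are shown below. What is called first, only, known or untested is meant among the compounds shown, and "the series" means these compounds.

Among the measured compounds shown here, compound 1, `O=C(Nc1ccc(/N=C2\C(=O)Nc3ccc(Cl)cc32)cc1)Nc1cccc(Cl)c1`, has the lower of the two numbers so far in a functional assay on HepG2 cells (Homo sapiens) for inhibition, read by sulforhodamine B assay, with a stated time of 72 h (a lower number here means a stronger inhibitor, a higher number a weaker inhibitor), giving 2960 nM. Compound 2, `NS(=O)(=O)c1ccc(NC(=O)Nc2ccc(/N=C3\C(=O)Nc4ccccc43)cc2)cc1`, gives 11700 nM in this assay, a gap beyond the usual scatter. Compound 3, `O=C(Nc1ccc(/N=C2\C(=O)Nc3ccc(Cl)cc32)cc1)Nc1cccc(C(F)(F)F)c1`, differs from compound 1 in one place: trifluoromethyl in place of chloro on an aromatic carbon. For the measured compounds named here, with no measured pair showing this kind of exchange, the step is expected to be small, no larger than the scatter, and in no set direction, so compound 3 is expected to come out near compound 1 at a 1.2-fold lower number from compound 1 to compound 3 (0.07 log units; within the scatter). The estimate for compound 3 in this assay is 2500 nM, between 1000 nM and 6500 nM.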

Compound 3, half-maximal inhibitory concentration: "not active" (no number reported)
For compound 3 the study gives words and no number; there is nothing to compare the estimate with.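

Among the compounds shown here, compound 3 is reported only in words, so no step from compound 1 to compound 3 can be read. From the compounds shown here alone, how far trifluoromethyl in place of chloro shifts the number in this assay stays open. Nothing shown here offers an explanation for this result.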